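Dropping the hydroxyl from the amine side chain of compound 1

The source may report more compounds than this note shows. Statements on the series, on what has been measured and on what is new or still open speak of the compounds shown alone.

Compound 1 `OC[C@H](NC1CCN(CCCc2c[nH]c3ccc(-n4ccnc4)cc23)CC1)c1ccccc1` is the most potent of the three measured compounds: in an assay on CHO cells for agonist activity at 5-hydroxytryptamine receptor 1D (Homo sapiens), read by GTPgammaS binding (a higher number here means that more compound is needed for the effect, a lower number that less compound is needed), compound 1 gives 0.8 nM. Compound 2 `CC(=O)Nc1ccc([C@H](C)NCC2CCN(CCCc3c[nH]c4ccc(-n5cnnc5)cc34)CC2)cc1` gives 3 nM, and compound 3 `OC[C@H](NC1CCN(CCCc2c[nH]c3ccc(Cn4cncn4)cc23)CC1)c1ccccc1` gives 32 nM. Going by the values given here, the one single-point step among them, a 40-fold higher number from compound 1 to compound 3 (1.60 log units; beyond the scatter), concerns the group on the aromatic ring of the shared core, not the amine side chain.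

Compound 4 `C[C@@H](NC1CCN(CCCc2c[nH]c3ccc(-n4ccnc4)cc23)CC1)c1ccccc1` differs from compound 1 at that side chain: 1-phenylethyl in place of 2-hydroxy-1-phenylethyl on an amine nitrogen. The hydroxyl that is lost is the side chain's only hydrogen-bond donor and acceptor. Among the compounds with values here, no measured pair isolates this change, so the step from compound 1 to compound 3 gives no direct guide, and compound 2 differs from compound 1 in several places at once.

The estimate for compound 4 is therefore a modest loss, a 3.1-fold higher number from compound 1 to compound 4 (0.49 log units; beyond the scatter), expected because compound 1 already sits at the low end with 0.8 nM. Compound 4 is estimated at 2.5 nM, within a range from 0.6 nM to 10 nM.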

Compound 4, half-maximal effective concentration: 6.2 nM
For compound 4 the middle estimate is 2.5-fold (0.39 log units) below the measured one, within the range that was stated.
By their numbers in this assay, from the lowest: compound 1; then compound 2; then compound 4; then compound 3.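

Going by these compounds alone, this is the first step at the amine side chain rather than on the aromatic ring of the shared core. In this assay, replacing 2-hydroxy-1-phenylethyl with 1-phenylethyl on the amine nitrogen gives a 7.8-fold higher number from compound 1 to compound 4 (0.89 log units; beyond the scatter), so the hydroxyl counts for something here, yet compound 4 keeps a single-digit nanomolar number at 6.2 nM and the side chain still works without it. Nothing measured here explains why the hydroxyl helps.

From the compounds shown here alone, whether the hydroxyl itself is what matters remains open, and a methoxy group, an amine or a longer chain carrying the hydroxyl at this place would test that. Going by these compounds, it is also open whether the step keeps its size with another group on the aromatic ring, such as the (1H-1,2,4-triazol-1-yl)methyl of compound 3.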